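The source may report more compounds than this note shows. Statements on the series, on what has been measured and on what is new or still open speak of the compounds shown alone.

Compound 2, whose structure is `CCCCCN(CCCCC)C(=O)N1CCN(C(=O)N(c2ccccc2)c2ccccc2)[C@H](C(=O)O)C1`, is the strongest of the three measured compounds in an assay for inhibition of Type-2 angiotensin II receptor (Rattus norvegicus) (a higher number here means a weaker inhibitor, a lower number a stronger inhibitor), where compound 2 gives 1.4 nM. Compound 1, `CCCCCN(CCCCC)C(=O)N1CCN(C(=O)N(c2ccccc2)c2ccccc2)[C@@H](C(=O)O)C1`, has the same atoms and bonds and gives 4.5 nM in this assay; the step of a 3.2-fold lower number from compound 1 to compound 2 (0.51 log units; beyond the scatter) rests on (the fact that compounds 1 and 2 differ only in the configuration as drawn). Compound 3, `CCCCCN(CCCCC)C(=O)N1CCN(C(=O)N(c2ccccc2)c2ccccc2)[C@H](CO)C1`, gives 30 nM in this assay, and the step of a 21-fold higher number from compound 2 to compound 3 (1.33 log units; beyond the scatter) shows how much the carboxy group matters.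

Compound 4, `CCCCCN(CCCCC)C(=O)N1CCN(C(=O)N(c2ccccc2)c2cccc(Br)c2)[C@H](C(=O)O)C1`, differs from compound 2 in one place: bromo in place of hydrogen on an aromatic carbon. Going by the values given here, neither measured step touches the aromatic rings, so no measured step bears on this change; the two steps concern configuration at a saturated ring carbon and the exchange of carboxy for hydroxymethyl, and nothing measured here tells how this assay answers a bromo group on a phenyl ring. The expectation for compound 4 is therefore a step of about a 1.1-fold higher number from compound 2 to compound 4 (0.03 log units; within the scatter), which is within the usual scatter. Compound 4 is expected to give about 1.5 nM in this assay, with a likely range from 0.5 nM to 5 nM.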

Compound 4, half-maximal inhibitory concentration: 0.6 nM
The estimate for compound 4 lay 2.5-fold (0.40 log units) above the measured number; the measured number falls inside the stated range.
By their numbers in this assay, from the lowest: compound 4; then compound 2; then compound 1; then compound 3.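

The phenyl ring is a part of the molecule that compounds 1 to 3 leave unchanged, and compound 4 gives the first reading there: going from phenyl to 3-bromophenyl produces a 2.3-fold lower number from compound 2 to compound 4 (0.37 log units; beyond the scatter) in this assay and so improves on an already strong inhibitor. Going by these compounds alone, this place on the ring therefore accepts a single bromine atom with a modest gain, whereas the earlier steps spoke only to the saturated ring carbon and its carboxy group. No available evidence bears on the reason for this step.

As far as these compounds go, whether a fluorine or chlorine atom, a methyl group or a methoxy group at the same place would do as well as bromo remains open. Also open, from the compounds shown here alone, is whether bromo would give a similar step on the other phenyl ring, or on compound 1 with its opposite configuration.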